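The source may report more compounds than this note shows. Statements on the series, on what has been measured and on what is new or still open speak of the compounds shown alone.

Measured compounds:
compound 1 `C#Cc1cn([C@@H]2O[C@H](CO)[C@@H](O)[C@H]2O)c2ncnc(C)c12` with 1440 nM; compound 2 `Cc1ncnc2c1c(-c1ccoc1)cn2[C@@H]1O[C@H](CO)[C@@H](O)[C@H]1O` with 98300 nM; compound 3 `C#Cc1cn([C@@H]2O[C@H](CO)[C@@H](O)[C@H]2O)c2nc(N)nc(OC)c12` with a limit of > 100000 nM.

The study compares two pairs of nucleosides in an ADME assay on MRC5 cells (Homo sapiens), read by MTT assay, with a stated time of 72 h; on this read-out lower numbers stand for stronger inhibition and higher numbers for weaker inhibition. Compound 1 and compound 2 share one core and differ in a single place: furan-3-yl in place of ethynyl on an aromatic carbon. This change gives a 68-fold higher number from compound 1 to compound 2 (1.83 log units; beyond the scatter), a large loss of cytotoxic effect in this assay.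

Compound 3 is built on a second core; how the two cores differ is not broken down here. Compound 3 carries the ethynyl group, and in this assay compound 3 gives only a limit, > 100000 nM. This value sits at the limit of > 100000 nM in this assay, at which 1 of the 3 values shown sits.

Compound 4 `COc1nc(N)nc2c1c(-c1ccoc1)cn2[C@@H]1O[C@H](CO)[C@@H](O)[C@H]1O` is the furan counterpart of compound 3 and has not yet been measured. Its relation to compound 3 is furan-3-yl in place of ethynyl on an aromatic carbon, the same change that separates compound 1 from compound 2, made at the same kind of position on the core.

Because compound 3 already gives only a limit at > 100000 nM, and because the same change gave a 68-fold higher number from compound 1 to compound 2 (1.83 log units; beyond the scatter), compound 4 is expected to show still weaker inhibition, a step that the limit leaves unreadable from compound 3 to compound 4. For compound 4 the estimated half-maximal inhibitory concentration is around 300000 nM, with a likely span from 100000 nM to 2000000 nM, and it is expected that this assay will most probably again report only a limit rather than a number for compound 4.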

Compound 4, half-maximal inhibitory concentration: > 100000 nM
Compound 4 was reported as a limit (the forecaster's own chance of this, stated with the estimate: 90%); the middle value does not contradict the limit.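

In this assay compound 4 gives > 100000 nM, which is a limit and not a number. Among the compounds shown here, compound 3 likewise gives a limit, > 100000 nM, so no step between compound 3 and compound 4 can be read. The compounds shown leave open whether furan-3-yl in place of ethynyl raises the number on the core of compound 3 as it does on the core of compound 1.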